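The source may report more compounds than this note shows. Statements on the series, on what has been measured and on what is new or still open speak of the compounds shown alone.

Compound 2, `N#Cc1cccc(C(=O)NCN2CCC(c3cccc[n+]3[O-])CC2)c1`, reaches 69% in a functional assay on HEK293 cells for agonist activity at D(4) dopamine receptor (Homo sapiens), read by FLIPR; a lower number here means a smaller maximal response, a higher number a larger maximal response. Compound 1, `O=C(NCN1CCC(c2cccc[n+]2[O-])CC1)c1ccccc1`, gives 63% in this assay, and the two values lie within the scatter of each other, so neither can be set apart. Going by the values given here, the single measured step, a number 6 percentage points higher from compound 1 to compound 2 (within the scatter), came with cyano in place of hydrogen on an aromatic carbon. Compound 3, `Cc1cc(C)cc(C(=O)NCN2CCC(c3cccc[n+]3[O-])CC2)c1`, is the next compound: 3,5-dimethylphenyl in place of 3-cyanophenyl on a carbonyl carbon. Among the compounds with values here, only that one step bears on the change to compound 3, since it altered the same phenyl ring and left the maximal response essentially unchanged, so a swap of one substituent pattern for another on that ring is expected to move the number little, if at all, beyond the scatter. Compound 3 is accordingly expected to give about 65%, in a range from 50% to 80%. This amounts to an expected step of a number 4 percentage points lower from compound 2 to compound 3 (within the scatter).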

Compound 3, largest response reached (reported as efficacy), in percent of the reference or control that the assay uses: 56%
Estimate against measurement, compound 3: 9 percentage points above; the range from low to high includes it.
By their numbers in this assay, from the lowest: compounds 3, 1 and 2 (each within the scatter of the next, the first and the last beyond it).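

In this assay, the group on the carbonyl carbon can move the maximal response beyond the scatter: a number 13 percentage points lower from compound 2 to compound 3 (beyond the scatter), with 3,5-dimethylphenyl in place of 3-cyanophenyl. Set against the plain phenyl of compound 1, the same group gives no separation, a number 7 percentage points lower from compound 1 to compound 3 (within the scatter), so only the two substituted rings stand apart, and compound 1 lies within the scatter of both. Nothing measured here accounts for this difference.

The compounds shown leave open whether a single methyl group would behave as the pair does, and how the maximal response would run with a methoxy group, an amine or a carboxylic acid on this phenyl ring. They also say nothing about changes to the shared core, since every step shown lies at this one ring.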